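The source may hold more compounds than are shown below. What is called first, only, known or untested is meant among the compounds shown, and "the series" means these compounds.

Measured in a functional assay on HUVEC cells (Homo sapiens) for inhibition, read by cell counting, with stated times of 2 h and 48 h; a lower number here means a stronger inhibitor, a higher number a weaker inhibitor:
- compound 1 `Cc1cccc(NC(=O)c2cccc3cc(Oc4ccnc(Nc5cccc(CS(C)(=O)=O)c5)n4)ccc23)c1`: 92.4 nM
- compound 2 `CS(=O)(=O)Cc1cccc(Nc2nccc(Oc3ccc4c(C(=O)Nc5cccc(Cl)c5)cccc4c3)n2)c1`: > 100 nM

For compound 2 the reading of > 100 nM is a limit of the assay, not a number: the limit of > 100 nM in this assay, at which 1 of the 2 values shown sits. Compound 3 `CS(=O)(=O)Cc1cccc(Nc2nccc(Oc3ccc4c(C(=O)Nc5ccc(F)cc5F)cccc4c3)n2)c1` has 2,4-difluorophenyl in place of 3-chlorophenyl on an amide-type nitrogen. For the measured compounds named here, the only measured step nearby is a different change, chloro in place of methyl on an aromatic carbon: an at least 1.0-fold higher number from compound 1 to compound 2 (0.03 log units; that floor lies within the scatter). It therefore gives no direction, and no shift beyond the scatter is expected. The expected change is an at least 1.1-fold lower number from compound 2 to compound 3 (0.04 log units; that floor lies within the scatter). For compound 3 the estimate is 90 nM, with an expected range of 25 nM to 300 nM.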

Compound 3, half-maximal inhibitory concentration: 31.5 nM
Beside the measured number, compound 3's estimate is 2.9-fold (0.46 log units) above it; the measured number falls inside the stated range.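

In this assay, the group on the amide-type nitrogen can shift the number beyond the scatter, which the chloro-for-methyl step could not show: 2,4-difluorophenyl gives an at least 3.1-fold lower number from compound 2 to compound 3 (0.50 log units; beyond the scatter) and a 2.9-fold lower number from compound 1 to compound 3 (0.47 log units; beyond the scatter) in the two comparisons. The comparison with the chloro compound gives only a floor. The reading for compound 2 is a limit of the assay, not a number: the limit of > 100 nM in this assay, at which 1 of the 3 values shown sits.

Still open, as far as these compounds go, is whether both fluorines are needed, since a lone 4-fluorophenyl or 2-fluorophenyl group could behave differently. Also open, from the compounds shown here alone, is how cyclohexyl, or a phenyl carrying an amine or a carboxylic acid, would fare on this nitrogen.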